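Hydroxy to Amino, Repeated on a Second Core

The compounds below may be only part of what the source reports. "The series", "measured", "known", "first", "only" and "open" are said of these compounds alone.

Compound 1 `COc1ccc(C(=O)c2ccc(OC)c3c2OC(C)(C)C=C3)c(NC(=O)CO)c1` and compound 2 `COc1ccc(C(=O)c2ccc(OC)c3c2OC(C)(C)C=C3)c(NC(=O)CN)c1` share one core, while compound 3 `C=C(c1ccc2c(c1)C=CC(C)(C)O2)c1ccc(OC)cc1NC(=O)CO` and the not yet measured compound 4 `C=C(c1ccc2c(c1)C=CC(C)(C)O2)c1ccc(OC)cc1NC(=O)CN` share another. In a functional assay on A549 cells (Homo sapiens) for antiproliferative activity, read by MTT assay, with a stated time of 48 h (a lower number here means a stronger inhibitor, a higher number a weaker inhibitor), compound 1 gives 80 nM, and compound 2 gives 270 nM. The change between them, (amino in place of hydroxy on a saturated chain carbon bound to a carbonyl carbon), made a step of a 3.4-fold higher number from compound 1 to compound 2 (0.53 log units; beyond the scatter). In this assay compound 3 gives 40 nM; its gap to compound 1 lies within the scatter, its gap to compound 2 beyond it. The difference between the core of compound 1 and the core of compound 3 is not broken down here. Compound 4 carries the same change that turned compound 1 into compound 2, namely (amino in place of hydroxy on a saturated chain carbon bound to a carbonyl carbon), and the place is described in the same words, so this is the same change, now on the second core. For the measured compounds named here, for compound 4 the expected step is a 3.3-fold higher number from compound 3 to compound 4 (0.51 log units; beyond the scatter), which rests on the only record of this change, a 3.4-fold higher number from compound 1 to compound 2 (0.53 log units; beyond the scatter). Compound 4 is therefore estimated at 130 nM, with a range from 60 nM to 300 nM.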

Compound 4, half-maximal inhibitory concentration: 60 nM
Beside the measured number, compound 4's estimate is 2.2-fold (0.34 log units) above it; measured number inside the range.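

On the second core, amino in place of hydroxy gave a step in this assay of a 1.5-fold higher number from compound 3 to compound 4 (0.18 log units; within the scatter), smaller in print than the step on the first core, yet the two cannot be told apart: the same change on two cores in this assay, a 3.4-fold higher number (0.53 log units; beyond the scatter) from compound 1 to compound 2 and a 1.5-fold higher number (0.18 log units; within the scatter) from compound 3 to compound 4, 2.3-fold (0.35 log units) apart, within the scatter of two such steps. The two records are therefore compatible with one shared step size, and they give no sign that the core alters what this change does. For the compounds shown here, they do not establish that the change carries over unaltered, since there are only two pairs in a single assay, one step lies beyond the scatter and the other within it, and the true size of the step remains loosely fixed.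

The compounds shown leave open how a substituted amine, a carboxylic acid or a longer chain would compare with hydroxy and amino on a saturated chain carbon bound to a carbonyl carbon, on either core. They also leave open whether the same change would give a similar step on any further core.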